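The source may report more compounds than this note shows. Statements on the series, on what has been measured and on what is new or still open speak of the compounds shown alone.

The three measured compounds share one core and differ only in the group on the carbonyl carbon. Compound 1 `Cc1ccc(C(=O)n2c(-c3cn(-c4ccccc4)nc3-c3ccc(F)cc3)nc3ccccc32)cc1` carries a 4-methylphenyl there, and in an ADME assay on HEK-293T cells (Homo sapiens) for cytotoxicity, read by MTT assay, with a stated time of 24 h (a higher number here means that more compound is tolerated, a lower number that less compound is tolerated), compound 1 gives 178000 nM. Compound 2 `Cc1cncc(C(=O)n2c(-c3cn(-c4ccccc4)nc3-c3ccc(F)cc3)nc3ccccc32)c1` carries a 5-methylpyridin-3-yl instead, and in this assay compound 2 gives 119000 nM. Compound 3 `Cc1ccc(C(=O)n2c(-c3cn(-c4ccccc4)nc3-c3ccc(F)cc3)nc3ccccc32)cn1` carries a 6-methylpyridin-3-yl, and in this assay compound 3 gives 137000 nM. The steps among them are a 1.5-fold lower number from compound 1 to compound 2 (0.17 log units; within the scatter), a 1.3-fold lower number from compound 1 to compound 3 (0.11 log units; within the scatter) and a 1.2-fold higher number from compound 2 to compound 3 (0.06 log units; within the scatter), each within the scatter, so compound 3 stands among three numbers that cannot be told apart.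

Compound 4 `Cc1ccc(C(=O)n2c(-c3cn(-c4ccccc4)nc3-c3ccc(C(F)(F)F)cc3)nc3ccccc32)cn1` keeps the 6-methylpyridin-3-yl of compound 3 and is altered elsewhere: trifluoromethyl in place of fluoro on an aromatic carbon. Among the measured compounds shown here, none of the measured steps concerns this part of the molecule; all of them vary the group on the carbonyl carbon, and all of them stayed within the scatter. The measured steps therefore give no direct guidance on the change, and the expectation rests on compound 3 alone, with a range widened to allow for an untested change. Compound 4 is expected in this assay to give 120000 nM, between 45000 nM and 320000 nM. That estimate means an expected step of a 1.1-fold lower number from compound 3 to compound 4 (0.06 log units; within the scatter), no larger than the scatter.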

Compound 4, half-maximal cytotoxic concentration: 153000 nM
For compound 4 the middle estimate is 1.3-fold (0.11 log units) below the measured one, and the stated range covers the measured number.
By their numbers in this assay, from the lowest: compounds 2, 3, 4 and 1 (each within the scatter of the next).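

Among the compounds shown here, the earlier compounds varied only the group on the carbonyl carbon, so compound 4 is the first to show a change on the 4-fluorophenyl: in this assay, trifluoromethyl in place of fluoro, on an aromatic carbon para to a large group, gives a 1.1-fold higher number from compound 3 to compound 4 (0.05 log units; within the scatter). At this position, then, a group of 4 heavy atoms can stand in place of one of 1 heavy atom without a step that can be told from the scatter, at least with the 6-methylpyridin-3-yl on the carbonyl carbon. Nothing available offers an explanation for this result.

The compounds shown leave open whether an amine, a carboxylic acid or a longer carbon chain on this aromatic carbon would also stay within the scatter of compound 3. They also leave open whether the same exchange of fluoro for trifluoromethyl would give a comparable step with the 4-methylphenyl of compound 1 or the 5-methylpyridin-3-yl of compound 2 on the carbonyl carbon.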